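A few compounds are considered here, and "the series" means these few. Any claim that something is new, unique, unknown or untested is made for them only; others in the source may bear on it.

Measured so far:
compound 1 `CCc1ccc2nc(C(=O)Nc3c(F)cc(-c4cccc(F)c4)cc3F)c(C)c(O)c2c1` — 11.2%
compound 2 `Cc1c(C(=O)Nc2c(F)cc(-c3cccc(F)c3)cc2F)nc2ccc(F)cc2c1O` — 2.65%
compound 3 `CCc1ccc2nc(C(=O)Nc3c(F)cc(-c4cccc(F)c4)cc3F)c(C)c(C(=O)O)c2c1` — 0.68%

In a functional assay on Hep 3B2 cells (Homo sapiens) for antiproliferative activity, read by MTT assay, with a stated time of 24 h, tested at 0.14 ug/mL (on this read-out lower numbers stand for a weaker effect and higher numbers for a stronger effect at the one concentration tested), compound 3 gives 0.68%, the lowest of the three numbers. Compound 2 lies within the scatter of it; compound 1 is set apart by the step of a number 10.5 percentage points lower from compound 1 to compound 3 (beyond the scatter), modest but beyond the scatter.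

Compound 4 `COc1ccc2nc(C(=O)Nc3c(F)cc(-c4cccc(F)c4)cc3F)c(C)c(C(=O)O)c2c1` differs from compound 3 by methoxy in place of ethyl on an aromatic carbon. For the measured compounds named here, no measured step exchanges these two groups. The nearest comparison is a number 8.6 percentage points lower from compound 1 to compound 2 (within the scatter), where the ethyl is likewise exchanged, there for fluoro, on an aromatic carbon, and the number stays within the scatter. In this assay no step beyond the scatter is therefore expected here either. Compound 4 is expected to give 2%, with a range from -8% to 12%. The expected step of a number 1.3 percentage points higher from compound 3 to compound 4 (within the scatter) lies within the scatter.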

Compound 4, a percentage reported as inhibition, at one concentration (the size of the read-out at that concentration, not a potency): 0.02%
Compound 4: middle estimate off by 2 percentage points, on the high side; the measured number falls inside the stated range.
By their numbers in this assay, from the lowest: compounds 4, 3, 2 and 1 (each within the scatter of the next, the first and the last beyond it).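

For the compounds shown here, with the carboxy group held in place, this is the first direct reading of methoxy in place of ethyl on this aromatic carbon: in this assay, the step is within the scatter (a number 0.7 percentage points lower from compound 3 to compound 4 (within the scatter)). The added hydrogen-bond acceptor of methoxy leaves no separable mark on the read-out, though compound 3 and compound 4 both stand at the low end of the series, which leaves little room for a drop to show. No measurement on hand accounts for this result.

Open, on these data alone, is whether methoxy reads the same with hydroxy in place of carboxy, as in compound 1. Also open, as far as these compounds go, is how an amine or a longer chain on this aromatic carbon would read.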